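A Para Methoxy Removed, an Acetamide Added

The source may hold more compounds than are shown below. What is called first, only, known or untested is meant among the compounds shown, and "the series" means these compounds.

This account follows a single step on one shared core. In a functional assay on HL-60 cells (Homo sapiens) for inhibition, read by MTT assay, with a stated time of 72 h (a lower number here means a stronger inhibitor, a higher number a weaker inhibitor), the three measured compounds spread widely. Compound 1 `COc1cc(OC)cc(N2CCN(C(=O)c3oc(C)nc3-c3cccc(F)c3)CC2)c1` gives 28.2 nM in this assay. Compound 2 `Cc1nc(-c2cccc(O)c2)c(C(=O)N2CCN(c3cccc(Cl)c3)CC2)o1` gives 105 nM in this assay, and the two values show compound 2 as the weaker of the pair. Compound 3 `COc1ccc(-c2nc(C)oc2C(=O)N2CCN(c3cccc(Cl)c3)CC2)cc1O` is reported only as "not active" (no number reported) in this assay, with no number attached, so it stands at the bottom of the set without a fixed place on the scale.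

Compound 4 `CC(=O)Nc1cccc(-c2nc(C)oc2C(=O)N2CCN(c3cccc(Cl)c3)CC2)c1` has not yet been measured. It differs from compound 3 in one place: 3-acetamidophenyl in place of 3-hydroxy-4-methoxyphenyl on an aromatic carbon. Going by the values given here, no measured pair in the set isolates this exact change, so no measured step can be borrowed. What the set does show is that compound 2, carrying a single substituent on this phenyl ring, gives 105 nM, while compound 3, carrying two, was not active. With compound 4 returning to a single substituent, a move back toward measurable inhibition is expected, though with wide uncertainty. Compound 4 is therefore expected to show 500 nM in this assay, within a range from 80 nM to 5000 nM.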

Compound 4, half-maximal inhibitory concentration: 208 nM
Beside the measured number, compound 4's estimate is 2.4-fold (0.38 log units) above it; the range from low to high includes it.
By their numbers in this assay, from the lowest: compound 1; then compounds 2 and 4 (each within the scatter of the next).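

In this assay compound 3 is reported as "not active" (no number reported), while compound 4, with 3-acetamidophenyl at the same place on the five-membered aromatic ring, gives 208 nM, so this position can carry a group other than 3-hydroxy-4-methoxyphenyl and still return a number. The size of the change from compound 3 to compound 4 cannot be read, as compound 3 has no number to set against the new value. The new result also shows that, on this phenyl ring, acetamido in place of hydroxy gives a 2.0-fold higher number from compound 2 to compound 4 (0.30 log units; within the scatter), so this assay does not separate these two groups and both compounds with a single substituent here keep measurable inhibition.

Nothing in the data available here gives a reason for these values, whether for the loss seen with compound 3 or for the values of compound 2 and compound 4.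

On these data alone, it remains open whether a primary amine or a carboxylic acid at the same ring carbon in place of the acetamido group, or a longer acyl chain on its nitrogen, would keep a value in this range.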